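This account rests on a few compounds, and the source may have more. Where it says the series, first, only, none or still open, it means among the compounds named here.

Measured compounds in an assay on membranes from HEK293 cells for displacement of a labelled ligand from adenosine receptor A2b (Homo sapiens), read by scintillation counting, with a stated time of 30 min, tested at 1 uM; a lower number here means less inhibition, a higher number more inhibition at the concentration tested (going by the name of the read-out):

compound 1 `CC1=C(C(=O)NC(C)C)C(c2ccco2)NC(=O)N1`: 2%
compound 2 `CC1=C(C(=O)NC(C)C)C(c2ccoc2)NC(=O)N1`: 3%
compound 3 `CC1=C(C(=O)NC(C)C)C(c2ccsc2)NC(=O)N1`: 3%

All three numbers sit close to the floor of this assay. Compound 1 stands alongside the other two: a number 1 percentage points higher from compound 1 to compound 2 (within the scatter) and a number 1 percentage points higher from compound 1 to compound 3 (within the scatter), and between the other pair no change at the digits printed from compound 2 to compound 3 (within the scatter). Within the data shown here, none of the three measured steps leaves the scatter, so the series so far shows no effect of swapping the ring on the saturated ring carbon.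

Compound 4 `CC1=C(C(=O)SC(C)C)C(c2ccco2)NC(=O)N1` is the next compound to be measured. Relative to compound 1 it differs in one place: isopropylsulfanyl in place of isopropylamino on a carbonyl carbon. Among the measured compounds shown here, no measured step touches this position; the three steps recorded all concern the ring on the saturated ring carbon, and they were all within the scatter. What can be carried over is only the level of the series, which has stayed near zero inhibition across every variation tried.

With nothing pointing in either direction, compound 4 is expected to give 3% (range 0% to 12%), that is, an expected step of a number 1 percentage points higher from compound 1 to compound 4 (within the scatter), which would stay inside the scatter.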

Compound 4, a percentage reported as inhibition, at one concentration (the size of the read-out at that concentration, not a potency): 22%
Compound 4: middle estimate off by 19 percentage points, on the low side; the whole stated range lies below it.
By their numbers in this assay, from the lowest: compounds 1, 2 and 3 (each within the scatter of the next); then compound 4.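

In this assay, among these compounds, the carbonyl substituent is the first position to move the read-out beyond the scatter, with isopropylsulfanyl in place of isopropylamino giving a number 20 percentage points higher from compound 1 to compound 4 (beyond the scatter) on the shared core. The ring swaps on the saturated ring carbon left the number within the scatter, so this position responds where that one has not so far, though the step remains modest. The exchange removes the hydrogen-bond donor of isopropylamino and brings in a hydrogen-bond acceptor along with sulfur, but no measurement here bears on why the number rises.

Open, going by these compounds, is whether the gain carries over to the furan-3-yl and thiophen-3-yl rings of compound 2 and compound 3. Also open, on these data alone, is how an isopropoxy group or a longer chain on the sulfur would read at this carbonyl carbon.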